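From phenylethynyl to isopropyl on an aromatic carbon

The compounds below may be only part of what the source reports. "The series", "measured", "known", "first", "only" and "open" are said of these compounds alone.

In a functional assay on K562 cells (Homo sapiens) for cytotoxicity, read by thymidine incorporation, with a stated time of 48 h (on this read-out lower numbers stand for stronger inhibition and higher numbers for weaker inhibition), compound 3 (`O=c1nc2c(ncn2Cc2ccccc2)c(C#Cc2ccccc2)n1Cc1ccccc1`) gives 0.7 ug/mL, the middle of the three numbers. Compound 1 (`O=C1Nc2c(ncn2Cc2ccccc2)C(c2ccccc2)N1Cc1ccccc1`) gives 0.2 ug/mL, and compound 2 (`CC(C)C1c2ncn(Cc3ccccc3)c2NC(=O)N1Cc1ccccc1`) gives 10 ug/mL. Compound 4 (`CC(C)c1c2ncn(Cc3ccccc3)c2nc(=O)n1Cc1ccccc1`) carries isopropyl in place of 2-phenylethynyl on an aromatic carbon. Within the data shown here, only one measured step bears on this, and it is an imperfect parallel: isopropyl in place of phenyl on a saturated ring carbon gave a 50-fold higher number from compound 1 to compound 2 (1.70 log units; beyond the scatter). Among the measured compounds shown here, no measured step shows this swap on an aromatic carbon, so a change in the same direction but of smaller size is expected in this assay. The expected step is a 7.1-fold higher number from compound 3 to compound 4 (0.85 log units; beyond the scatter). Compound 4 is estimated at 5 ug/mL, within a range of 1 ug/mL to 20 ug/mL.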

Compound 4, half-maximal inhibitory concentration: > 10 ug/mL
Compound 4: only a limit was reported (the forecaster's own chance of this, stated with the estimate: 5%); middle value at least 2.0-fold (0.30 log units) away from the limit.
By their numbers in this assay, from the lowest: compound 1; then compound 3; then compound 2.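

Compound 4 gives > 10 ug/mL in this assay, and this value is a limit of the assay. On this aromatic carbon next to the ring nitrogen, isopropyl in place of 2-phenylethynyl brings an at least 14-fold higher number from compound 3 to compound 4 (1.15 log units; beyond the scatter), so the large step seen on the saturated ring carbon has a counterpart here. From the compounds shown here alone, how much higher the number for compound 4 lies stays unknown.

Going by these compounds, whether the lower number of compound 3 goes with its aromatic ring or its triple bond remains open; phenyl or 2-phenylethyl on this carbon would bear on that. On these data alone, what an amine there would give is also open.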